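Nitro in place of fluoro: compound 2 to compound 3

The compounds below may be only part of what the source reports. "The series", "measured", "known", "first", "only" and "open" are said of these compounds alone.

Measured in an ADME assay on J774.A1 cells (Mus musculus) for cytotoxicity, read by MTT assay, with a stated time of 48 h (a higher number here means that more compound is tolerated, a lower number that less compound is tolerated), so far:
compound 1 (`Cc1ccc(-n2cc(COC(=O)c3c(C)nc4ccccc4c3-c3ccccc3)nn2)cc1`): 39000 nM
compound 2 (`Cc1nc2ccccc2c(-c2ccccc2)c1C(=O)OCc1cn(Cc2ccc(F)cc2)nn1`): "not determined" (no result reported)

Compound 2 has no place on the numbers: in this assay compound 2 is reported as "not determined" (no result reported) and so offers no reference point. For the measured compounds named here, compound 1 at 39000 nM is the only number available, and the series holds no step between two measured compounds.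

The change to follow runs from compound 2 to compound 3 (`Cc1nc2ccccc2c(-c2ccccc2)c1C(=O)OCc1cn(Cc2ccc([N+](=O)[O-])cc2)nn1`). It puts nitro in place of fluoro on an aromatic carbon, para to a large group (nitro in place of fluoro on an aromatic carbon), which turns 4-fluorobenzyl into 4-nitrobenzyl. No measured effect of this change is available, so the size of the step in this assay cannot be read from the data. With compound 1 at 39000 nM as the sole anchor, no shift beyond the usual scatter is expected, and the uncertainty stays wide in both directions. Compound 3 is estimated at 30000 nM in this assay, with an expected range from 10000 nM to 90000 nM for a repeated measurement.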

Compound 3, half-maximal cytotoxic concentration: 42000 nM
The estimate for compound 3 lay 1.4-fold (0.15 log units) below the measured number, and the stated range covers the measured number.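

In this assay the series now has its first readable step, a 1.1-fold higher number from compound 1 to compound 3 (0.03 log units; within the scatter), with 4-nitrobenzyl in place of 4-methylphenyl on an aromatic nitrogen. This pair shows that the shared core tolerates a substituent there that differs in both its linkage and its ring substituent while the two compounds stay within the scatter of each other, although one pair cannot establish a general pattern. The step from fluoro to nitro cannot be read, as compound 2 has no number, and no evidence is available to explain the closeness of compound 1 and compound 3.

Going by these compounds, the effect of the change from 4-fluorobenzyl to 4-nitrobenzyl therefore remains open, and so does the separate contribution of the benzyl link and the nitro group to the step between compound 1 and compound 3. On these data alone, it is also open whether an amine or a carboxylic acid in place of nitro, or a longer chain in place of the benzyl link, would leave the number within the scatter.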